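Replacing Chloro by Isopropylamino: Expected Vero Cytotoxicity

The source may report more compounds than this note shows. Statements on the series, on what has been measured and on what is new or still open speak of the compounds shown alone.

Compound 3 `CC(C)Nc1cc(Cl)cc2c(-c3ccnc(NC4CCCC4)n3)c(-c3ccc(F)cc3)nn12` was examined in an ADME assay on Vero cells (Chlorocebus sabaeus) for cytotoxicity; on this read-out lower numbers stand for higher toxicity in this test and higher numbers for lower toxicity in this test. In this assay compound 3 gives > 40000 nM, which is a limit of the assay rather than a number. Its close relatives sit at the same limit. Compound 1 `CC(C)Nc1ccn2nc(-c3ccc(F)cc3)c(-c3ccnc(NC4CCCC4)n3)c2c1` gives > 40000 nM, a limit. Compound 2 `Fc1ccc(-c2nn3c(NC4CC4)cc(Cl)cc3c2-c2ccnc(NC3CCCC3)n2)cc1` gives > 40000 nM, also a limit. Going by the values given here, the one measured step that alters a single group, a step that the two limits leave unreadable from compound 2 to compound 3, cannot be read because of the limit of > 40000 nM in this assay, at which 3 of the 3 values shown sit. Compound 4 `CC(C)Nc1cc(NC(C)C)n2nc(-c3ccc(F)cc3)c(-c3ccnc(NC4CCCC4)n3)c2c1` differs from compound 3 in one place: isopropylamino in place of chloro on an aromatic carbon. Among the compounds with values here, no measured step covers this particular exchange, and the single measured step that exists is unreadable, so the series gives no direction for it. The step from compound 3 to compound 4 is therefore expected to be about a step that the limit leaves unreadable from compound 3 to compound 4, that is, no change beyond the scatter. Compound 4 is accordingly estimated at 60000 nM, with a range from 25000 nM to 150000 nM, and it is expected most likely to be reported only as a limit once more.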

Compound 4, half-maximal cytotoxic concentration: > 40000 nM
Compound 4: no number, only a limit; the forecaster's own chance of this, stated with the estimate: 85%; the middle value lies beyond the limit too.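

Compound 4 yields no readable step in this assay, either against compound 3 or against compound 1, because the values offer only limits: the limit of > 40000 nM in this assay, at which 4 of the 4 values shown sit. The compounds shown leave open how far either exchange on the aromatic carbon actually shifts cytotoxicity.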